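The compounds below may be only part of what the source reports. "The series", "measured", "known", "first", "only" and "open" are said of these compounds alone.

The shared core, a fused two-ring system carrying two amino groups and a phenyl group, is present in compound 1 `CCOC(=O)[C@H](CCC(=O)O)NC(=O)c1ccc(Sc2nc3cc(N)cc(N)c3nc2-c2ccccc2)cc1`, compound 2 `Nc1cc(N)c2nc(-c3ccccc3)c(Sc3ccc(F)cc3)nc2c1` and compound 3 `CCOC(=O)[C@H](CCC(=O)O)NC(=O)c1ccc(Oc2nc3cc(N)cc(N)c3nc2-c2ccccc2)cc1`. The three were tested in a functional assay on NCI-H322M cells (Homo sapiens) for inhibition, read by sulforhodamine B assay, with a stated time of 48 h; a higher number here means that more compound is tolerated, a lower number that less compound is tolerated. In this assay compound 1 gives < 100000 nM, which is a limit of the assay and not a number. In this assay compound 3 likewise gives < 100000 nM, again a limit rather than a number. Both compound 1 and compound 3 therefore sit at the limit of < 100000 nM in this assay, at which 2 of the 3 values shown sit. Compound 2 is the only one of the three with a real number: in this assay compound 2 gives 70800 nM, so it stands alone among the values shown.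

Compound 4 `Nc1cc(N)c2nc(-c3ccccc3)c(NCc3ccc(F)cc3)nc2c1` has not yet been measured. It differs from compound 2 in one place: (4-fluorobenzyl)amino in place of (4-fluorophenyl)sulfanyl on an aromatic carbon. For the measured compounds named here, no step between two measured compounds is available to guide the size of this change, so the expectation rests on compound 2 alone. The step from compound 2 to compound 4 is expected to be modest, in either direction, and most likely to stay within the usual scatter. Compound 4 is therefore expected to give about 65000 nM in this assay, with a range from 25000 nM to 150000 nM. The step that this estimate means is a 1.1-fold lower number from compound 2 to compound 4 (0.04 log units; within the scatter), expected to be small.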

Compound 4, concentration lethal to 50% of the cells: 40700 nM
Beside the measured number, compound 4's estimate is 1.6-fold (0.20 log units) above it; low and high end bracket the measured number.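

At this position, on an aromatic carbon next to the ring nitrogen, the series now has its first measured step: in this assay, the change gives a 1.7-fold lower number from compound 2 to compound 4 (0.24 log units; within the scatter). The swap alters the link to the 4-fluorophenyl ring and brings in a hydrogen-bond donor that (4-fluorophenyl)sulfanyl lacks, yet the two compounds cannot be told apart in this read-out, so this position accepts at least this one change without a shift beyond the scatter. The two remaining compounds offer no second step to set beside this one, and their values are limits, not numbers: the limit of < 100000 nM in this assay, at which 2 of the 4 values shown sit.

From the compounds shown here alone, this single step changes the linking atom and the length of the link together, so the effect of each alone stays open; (4-fluorophenyl)amino, which keeps the nitrogen link without the extra carbon, or (4-fluorobenzyl)sulfanyl, which keeps the sulfur with it, would separate the two. Also open, going by these compounds, is whether the position responds more strongly to groups further from these two, such as a plain amine, a carboxylic acid or a longer chain without the fluorinated ring.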